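A trimethylammonium-for-hydroxy Swap Repeated on a Second Core

This account rests on a few compounds, and the source may have more. Where it says the series, first, only, none or still open, it means among the compounds named here.

The measured compounds are:

compound 1, `O=c1cc(-c2ccc(O)c(O)c2)oc2cc(OCCO)ccc12`, 16400 nM;
compound 2, `C[N+](C)(C)CCCOc1ccc2c(=O)cc(-c3ccc(O)c(O)c3)oc2c1`, 37300 nM;
compound 3, `O=c1c(OCCO)c(-c2ccc(O)c(O)c2)oc2cc(O)ccc12`, 21700 nM.

All three were tested in a functional assay for inhibition, with Rattus norvegicus as the target, using microsomes; a lower number here means a stronger inhibitor, a higher number a weaker inhibitor. Compound 1 and compound 2 share a core, and the change between them is a group of 5 heavy atoms (4 carbon, 1 nitrogen; no ring) in place of one oxygen atom, on a saturated chain carbon, two bonds along the chain from an oxygen on an aromatic ring. This change gave a 2.3-fold higher number from compound 1 to compound 2 (0.36 log units; beyond the scatter). Compound 3 has a different core; how it differs from compound 1 is not broken down here, and their values lie within the scatter of each other, as do the values of compound 3 and compound 2.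

Compound 4, `C[N+](C)(C)CCCOc1c(-c2ccc(O)c(O)c2)oc2cc(O)ccc2c1=O`, has not yet been measured in this assay. It stands to compound 3 as compound 2 stands to compound 1: the change is a group of 5 heavy atoms (4 carbon, 1 nitrogen; no ring) in place of one oxygen atom, on a saturated chain carbon, two bonds along the chain from an oxygen on an aromatic ring, at the same place, so it is the same change. Because the step of a 2.3-fold higher number from compound 1 to compound 2 (0.36 log units; beyond the scatter) was modest but beyond the scatter, compound 4 is expected to show a step of a 2.3-fold higher number from compound 3 to compound 4 (0.36 log units; beyond the scatter) relative to compound 3, with the same direction. The estimate for compound 4 in this assay is 50000 nM, expected to fall between 25000 nM and 100000 nM.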

Compound 4, half-maximal inhibitory concentration: 3800 nM
Estimate against measurement, compound 4: 13-fold (1.12 log units) above; the whole stated range lies above it.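

On the core of compound 3, replacing the hydroxy with the charged group of 5 heavy atoms gave a 5.7-fold lower number from compound 3 to compound 4 (0.76 log units; beyond the scatter) in this assay, the opposite direction to the step seen on the core of compound 1. The change therefore has no single transferable effect across these two cores, and the difference between the two steps is larger than repeated measurement would explain: the same change on two cores in this assay, a 2.3-fold higher number (0.36 log units; beyond the scatter) from compound 1 to compound 2 and a 5.7-fold lower number (0.76 log units; beyond the scatter) from compound 3 to compound 4, 13-fold (1.11 log units) apart, beyond the scatter of two such steps

Among these compounds, with only one matched pair on each core, this shows that the step on one core failed to predict the step on the other, but it does not show which feature of the two cores accounts for the reversal, or how general the reversal is.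

The compounds shown leave open whether the same reversal would appear with other groups at the end of the chain, such as a tertiary amine or a carboxylic acid, or with a longer chain. They also leave open whether it would appear on any third core.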